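The source may report more compounds than this note shows. Statements on the series, on what has been measured and on what is new or still open speak of the compounds shown alone.

Measured so far:
compound 1, `COc1ccc(C2C(C#N)=C(N)N(c3cc(OC)c(OC)c(OC)c3)C3=C2C(=O)CC(C)(C)C3)cc1`: 15%
compound 2, `COc1cc(N2C(N)=C(C#N)C(/C=C/c3ccccc3)C3=C2CC(C)(C)CC3=O)cc(OC)c1OC`: 40%
compound 3, `COc1cc(N2C(N)=C(C#N)C(c3c(OC)ccc4ccccc34)C3=C2CC(C)(C)CC3=O)cc(OC)c1OC`: 30%

All values are from a functional assay on Ehrlich cells (Mus musculus) for cytotoxicity, tested at 100 ug/mL; a lower number here means a weaker effect, a higher number a stronger effect of the compound at the concentration tested. Compound 3 stands second highest of the three numbers: a number 10 percentage points lower from compound 2 to compound 3 (within the scatter), so compound 2 and compound 3 cannot be told apart here, whereas a number 15 percentage points higher from compound 1 to compound 3 (beyond the scatter).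

Compound 4, `COc1cc(N2C(N)=C(C#N)C(c3ccccc3O)C3=C2CC(C)(C)CC3=O)cc(OC)c1OC`, is not yet measured. It differs from compound 3 in one place: 2-hydroxyphenyl in place of 2-methoxynaphthalen-1-yl on a saturated ring carbon.

Among the compounds with values here, two measured steps bear on this change. a number 15 percentage points higher from compound 1 to compound 3 (beyond the scatter) shows a modest rise when the 4-methoxyphenyl group is exchanged for the 2-methoxynaphthalen-1-yl group with its two six-membered aromatic rings. a number 10 percentage points lower from compound 2 to compound 3 (within the scatter) stays within the scatter. The move to compound 4 returns to a group with one six-membered aromatic ring, closer in size to that of compound 1, which gives 15% in this assay. A modest fall is therefore expected. For compound 4 the expected step is a number 10 percentage points lower from compound 3 to compound 4 (within the scatter). Compound 4 is estimated at 20%, with a range from 5% to 35%.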

Compound 4, a percentage reported as activity, at one concentration (the size of the read-out at that concentration, not a potency): 10%
The estimate for compound 4 lay 10 percentage points above the measured number; the measured number falls inside the stated range.
By their numbers in this assay, from the lowest: compounds 4 and 1 (each within the scatter of the next); then compounds 3 and 2 (each within the scatter of the next).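

In this assay, within the data shown here, replacing the 2-methoxynaphthalen-1-yl group on the saturated ring carbon gives a number 20 percentage points lower from compound 3 to compound 4 (beyond the scatter), the first step at this position that removes an aromatic ring and adds a hydrogen-bond donor together. The 2-hydroxyphenyl group also gives a number 30 percentage points lower from compound 2 to compound 4 (beyond the scatter), yet it cannot be told apart from the 4-methoxyphenyl group, with a number 5 percentage points lower from compound 1 to compound 4 (within the scatter), so moving the oxygen substituent and exchanging methoxy for hydroxy together leave no readable change on a single-ring aryl group. No measurement on hand explains these steps.

The compounds shown do not separate the loss of the second aromatic ring from the gain of the hydroxyl group, a question that 2-methoxyphenyl or 2-hydroxynaphthalen-1-yl would address. Going by these compounds, how a non-aromatic group such as cyclohexyl would behave at this carbon also remains open.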